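Thiophen-3-yl replaces 3,5-dimethoxyphenyl on an inactive scaffold

The compounds below may be only part of what the source reports. "The series", "measured", "known", "first", "only" and "open" are said of these compounds alone.

Compound 1 `Cc1cc(Cc2cccc(F)c2)c(=O)n(CC(=O)Nc2ccc(Br)cc2)n1` – > 50000 nM
Compound 2 `Cc1cc(Cc2cccc(Cl)c2)c(=O)n(CC(=O)Nc2ccc(Br)cc2)n1` – > 50000 nM
Compound 3 `COc1cc(Cc2cc(C)nn(CC(=O)Nc3ccc(Br)cc3)c2=O)cc(OC)c1` – > 50000 nM

In a functional assay on HL-60 cells (Homo sapiens), read by calcium flux (on this read-out higher numbers stand for an effect only at larger amounts of compound and lower numbers for an effect already at smaller amounts), compound 3 reaches only the limit of the assay, > 50000 nM, and not a number. Compound 1 likewise stops at the limit > 50000 nM. Compound 2 also gives only the limit > 50000 nM. The change to compound 4 `Cc1cc(Cc2ccsc2)c(=O)n(CC(=O)Nc2ccc(Br)cc2)n1` is thiophen-3-yl in place of 3,5-dimethoxyphenyl on a saturated chain carbon bound to an aromatic carbon. Two earlier steps touched the same place: a step that the two limits leave unreadable from compound 1 to compound 3 and a step that the two limits leave unreadable from compound 2 to compound 3; both run between limits, so their size cannot be read, because of the limit of > 50000 nM in this assay, at which 3 of the 3 values shown sit. Nothing among these values points toward an effect at smaller amounts, so compound 4 is expected to stay near the limit, a step that the limit leaves unreadable from compound 3 to compound 4. The estimate for compound 4 is 60000 nM, within 20000 nM to 200000 nM.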

Compound 4, half-maximal effective concentration: > 50000 nM
Compound 4 ended at the assay's limit; the forecaster's own chance of this, stated with the estimate: 85%; the middle value is on the limit's open side.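

In this assay compound 4 gives > 50000 nM, a limit and not a number. Going by these compounds alone, no step from compound 1, compound 2 or compound 3 to compound 4 can be read. The compounds shown leave open whether any group on this saturated chain carbon gives a measurable effect.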